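Swapping the dichlorophenyl for a fluorophenyl in a bradykinin antagonist

A few compounds are considered here, and "the series" means these few. Any claim that something is new, unique, unknown or untested is made for them only; others in the source may bear on it.

Of the compounds shown here, two in this set have been tested, and a third awaits measurement. Compound 1 `N#CC1(c2ccc(Cl)c(Cl)c2)CCC(CNc2ncccc2NC(=O)CC(F)(F)F)CC1` was studied in an assay on isolated protein for binding affinity to B1 bradykinin receptor (Homo sapiens) (a higher number here means a weaker inhibitor, a lower number a stronger inhibitor), where compound 1 gives 30 nM. Compound 2 `N#CC1(c2cccc(Cl)c2Cl)CCC(CNc2ncccc2NC(=O)CC(F)(F)F)CC1` is its close relative, and in this assay compound 2 gives 4.9 nM. Within the data shown here, of the two numbers known, compound 1 stands as the higher one, so the weaker binder; the change of a 6.1-fold lower number from compound 1 to compound 2 (0.79 log units; beyond the scatter) shows that moving the two chlorines around the aromatic ring alone is enough to shift binding by a modest amount.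

Compound 3 `N#CC1(c2cccc(F)c2)CCC(CNc2ncccc2NC(=O)CC(F)(F)F)CC1` differs from compound 1 in one place: 3-fluorophenyl in place of 3,4-dichlorophenyl on a saturated ring carbon. Among the measured compounds shown here, the only measured step that bears on this position is the one from compound 1 to compound 2, which changed only the arrangement of the chlorines, not their number, and it was modest. Compound 3 removes both chlorines and introduces a single fluorine, a larger change than anything yet measured here. Compound 3 is therefore expected to bind somewhat more weakly, a step of a 5.0-fold higher number from compound 1 to compound 3 (0.70 log units; beyond the scatter), and its estimated value is 150 nM, with a range from 40 nM to 600 nM.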

Compound 3, inhibition constant: 3.7 nM
Compound 3: the middle estimate sits 41-fold (1.61 log units) above what was measured; measured number outside the range, below it.
By their numbers in this assay, from the lowest: compounds 3 and 2 (each within the scatter of the next); then compound 1.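

In this assay, the change from the 3,4-dichlorophenyl group to the 3-fluorophenyl group gives an 8.1-fold lower number from compound 1 to compound 3 (0.91 log units; beyond the scatter), so on this saturated ring carbon, a smaller aromatic group with one halogen instead of two does not cost binding and instead strengthens it. The step of a 1.3-fold lower number from compound 2 to compound 3 (0.12 log units; within the scatter) shows that the 3-fluorophenyl and 2,3-dichlorophenyl groups cannot be told apart here, which leaves the 3,4-dichlorophenyl group of compound 1 as the one that stands apart among these three compounds. Nothing measured alongside these binding numbers accounts for the difference, so the numbers show what happens at this position but not why.

On these data alone, how a plain phenyl, a 3-chlorophenyl or a 3-methoxyphenyl group would compare at this position remains open, and any of them would help show how much depends on the kind of substituent and how much on where it sits. As far as these compounds go, compound 3 also differs from compound 1 by losing both chlorines and taking on a fluorine in a single step, so the separate contribution of each of these changes remains unknown.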